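Working notes on the shared core: aryl to cyclohexyl step

The source may hold more compounds than are shown below. What is called first, only, known or untested is meant among the compounds shown, and "the series" means these compounds.

Measured so far, in a functional assay on A549 cells (Homo sapiens) for antiproliferative activity, read by MTT assay, with a stated time of 48 h; a lower number here means a stronger inhibitor, a higher number a weaker inhibitor:
compound 1 `O=C(Nc1cccc(Cl)c1)Nc1cccc(NC(=O)c2ccccn2)c1` gives 2850 nM
compound 2 `O=C(Nc1ccc([N+](=O)[O-])cc1)Nc1cccc(NC(=O)c2ccccn2)c1` gives 320 nM
compound 3 `Cc1ccc(NC(=O)Nc2cccc(NC(=O)c3ccccn3)c2)cc1` gives 20 nM

Compound 3 stands lowest of the three, and both gaps are beyond the scatter: a 16-fold lower number from compound 2 to compound 3 (1.20 log units; beyond the scatter) and a 140-fold lower number from compound 1 to compound 3 (2.15 log units; beyond the scatter). The remaining step, an 8.9-fold lower number from compound 1 to compound 2 (0.95 log units; beyond the scatter), is smaller.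

Compound 4 `O=C(Nc1cccc(NC(=O)c2ccccn2)c1)NC1CCCCC1` differs from compound 3 by cyclohexyl in place of 4-methylphenyl on an amide-type nitrogen. Within the data shown here, none of the measured steps makes this kind of change; each keeps the aromatic ring and alters only its substituent, so they bear on the question only by showing that this position is sensitive, with differences ranging from modest to large. On these data alone, replacing the aromatic ring itself is untested. Compound 4 is therefore expected to move upward, by a 7.5-fold higher number from compound 3 to compound 4 (0.88 log units; beyond the scatter), to an estimated 150 nM, within 30 nM to 1500 nM.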

Compound 4, half-maximal inhibitory concentration: 6260 nM
Compound 4: the middle estimate sits 42-fold (1.62 log units) below what was measured, outside the stated range (above it).
By their numbers in this assay, from the lowest: compound 3; then compound 2; then compound 1; then compound 4.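

Cyclohexyl on the amide-type nitrogen gives a higher number than each of the three aromatic groups: a 310-fold higher number from compound 3 to compound 4 (2.50 log units; beyond the scatter), a 20-fold higher number from compound 2 to compound 4 (1.29 log units; beyond the scatter) and a 2.2-fold higher number from compound 1 to compound 4 (0.34 log units; beyond the scatter). All three steps are beyond the scatter, so compound 4 stands highest of the four, and the aromatic ring at this position matters as well as its substituent. Nothing available here accounts for this loss.

Still open, on these data alone, is whether 4-methylcyclohexyl or benzyl on the same nitrogen would recover any of it. As far as these compounds go, how an amine or a carboxylic acid on the 4-methylphenyl ring would read is also open.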